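Trading 1H-imidazol-4-yl for methyl on a shared core

The source may report more compounds than this note shows. Statements on the series, on what has been measured and on what is new or still open speak of the compounds shown alone.

Of the compounds shown here, two built on a shared core have been measured so far. In a functional assay on cells (Erythrocyte, Rattus norvegicus) for inhibition, read by hemolysis, with a stated time of 1 h (on this read-out lower numbers stand for stronger inhibition and higher numbers for weaker inhibition), compound 1 (`COc1cc(OC)c(OC)cc1/C=C/C(=O)c1cc(OC(C)=O)ccc1OC(C)=O`) gives 2.33 ug/mL and compound 2 (`COc1cc(OC)c(OC)cc1/C=C/C(=O)c1ccc(-c2c[nH]cn2)cc1`) gives 2.48 ug/mL as the half-maximal inhibitory concentration. These two numbers lie within the usual scatter of repeated measurements, so compound 2 stands level with compound 1.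

Compound 3 (`COc1cc(OC)c(OC)cc1/C=C/C(=O)c1ccc(C)cc1`) differs from compound 2 by a single swap (methyl in place of 1H-imidazol-4-yl on an aromatic carbon), with methyl in place of 1H-imidazol-4-yl on an aromatic carbon. For the measured compounds named here, no measured pair shows this swap, so the data give no direct guide to its effect in this assay and any forecast is tentative. Going by the values given here, the only hint is that compound 1 at 2.33 ug/mL and compound 2 at 2.48 ug/mL carry different groups and still read alike. A small shift therefore seems likely, towards a slightly higher number if there is one at all. The expected step is a 1.2-fold higher number from compound 2 to compound 3 (0.08 log units; within the scatter) and is estimated to stay close to the scatter. For compound 3 the estimated value is 3 ug/mL with an expected range of 1.2 ug/mL to 7.5 ug/mL once it is measured.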

Compound 3, half-maximal inhibitory concentration: 2.24 ug/mL
Beside the measured number, compound 3's estimate is 1.3-fold (0.13 log units) above it; the measured number falls inside the stated range.
By their numbers in this assay, from the lowest: compounds 3, 1 and 2 (each within the scatter of the next).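

In this assay, for the compounds shown here, putting methyl in place of 1H-imidazol-4-yl on an aromatic carbon, para to a large group, gives a 1.1-fold lower number from compound 2 to compound 3 (0.04 log units; within the scatter) and so provides the first direct reading of a change at this position: compound 2 and compound 3 stand level. The swap removes a five-membered aromatic ring with 2 hetero atoms, along with 1 hydrogen-bond donor and 1 hydrogen-bond acceptor, and leaves a single carbon, yet the read-out does not separate the two compounds. This pair therefore shows that, at this position, neither the ring nor its donor and acceptor is required for a reading at this level, although no measurement at hand bears on why the two groups read alike.

With only these two groups shown at this position, it remains open whether the group placed here matters at all in this assay. An amine, a carboxylic acid or a longer alkyl chain could read level with methyl or depart from it, and a compound with plain hydrogen here would show what either group contributes.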